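Methyl to Hydrogen on a Phenolic Oxygen in Benzofuran Ketones

The source may hold more compounds than are shown below. What is called first, only, known or untested is meant among the compounds shown, and "the series" means these compounds.

Three compounds have been examined so far, and a fourth awaits testing. Compound 2 `CCc1oc2ccc(OC)cc2c1C(=O)c1ccc(O)cc1` and compound 3 `CCc1oc2ccc(O)cc2c1C(=O)c1ccc(O)cc1` share a core, and in an assay for inhibition of solute carrier family 22 member 12 (Homo sapiens), read by scintillation counting, with a stated time of 60 min (on this read-out higher numbers stand for weaker inhibition and lower numbers for stronger inhibition), compound 2 gives 2460 nM. Compound 3 differs from compound 2 by hydrogen in place of methyl on an oxygen on an aromatic ring, and in this assay compound 3 gives 2490 nM. The step of a 1.0-fold higher number from compound 2 to compound 3 (0.01 log units; within the scatter) shows that this change leaves the result essentially where it was.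

Compound 1 `CCc1cc2c(C(=O)c3ccc(OC)cc3)cc(OC)cc2o1` belongs to a different core; the difference between the two cores is not broken down here. For compound 1 the result in this assay is "not determined" (no result reported), so no number is available for it. Compound 4 `CCc1cc2c(C(=O)c3ccc(O)cc3)cc(OC)cc2o1` is related to compound 1 by hydrogen in place of methyl on an oxygen on an aromatic ring. Going by the values given here, this is the same change as the one from compound 2 to compound 3, made at the same kind of place.

Among the compounds with values here, because compound 1 has no measured value, no step can be computed from compound 1 to compound 4, and the expectation for compound 4 rests on the measured compounds alone. Compound 4 carries the same free hydroxy group on the ketone-bearing ring that compound 2 and compound 3 carry, and those two compounds gave numbers close to each other. Compound 4 is therefore expected to give about 3000 nM in this assay, with a range of 700 nM to 13000 nM to allow for the change of core, which is not characterised by any measured pair here.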

Compound 4, half-maximal inhibitory concentration: 19700 nM
Compound 4: the middle estimate sits 6.6-fold (0.82 log units) below what was measured; measured number outside the range, above it.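

Going by these compounds alone, no step from compound 1 to compound 4 can be read: in this assay compound 1 carries the entry "not determined" (no result reported) and so offers no number to set against compound 4. The compounds shown leave open whether going from methoxy to hydroxy on the core of compound 1 does as little as a 1.0-fold higher number from compound 2 to compound 3 (0.01 log units; within the scatter). Nothing available here accounts for the result of compound 4.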